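The compounds below may be only part of what the source reports. "The series", "measured", "known", "first", "only" and "open" are said of these compounds alone.

Within the data shown here, in a functional assay for antagonist activity at transient receptor potential cation channel subfamily V member 1 (Rattus norvegicus) (a lower number here means a stronger inhibitor, a higher number a weaker inhibitor), compound 3 `CC(C)(C)c1ccc(NC(=O)c2ccc(-c3ncccc3NS(=O)(=O)c3ccccc3)cc2)cc1` gives 166 nM, the highest of the three numbers measured so far. Compound 1 `CCS(=O)(=O)Nc1cccnc1-c1ccc(C(=O)Nc2ccc(C(C)(C)C)cc2)cc1` gives 4 nM and compound 2 `CC(C)(C)c1ccc(NC(=O)c2ccc(-c3ncccc3N(S(C)(=O)=O)S(C)(=O)=O)cc2)cc1` gives 0.4 nM, so that a 42-fold higher number from compound 1 to compound 3 (1.62 log units; beyond the scatter) and a 420-fold higher number from compound 2 to compound 3 (2.62 log units; beyond the scatter), while a 10-fold lower number from compound 1 to compound 2 (1.00 log units; beyond the scatter). Compound 4 `CN(C)Cc1cccnc1-c1ccc(C(=O)Nc2ccc(C(C)(C)C)cc2)cc1` differs from compound 3 in one place: (dimethylamino)methyl in place of (phenylsulfonyl)amino on an aromatic carbon. Among the measured compounds shown here, none of the three measured steps bears directly on this change, since each of them only varies what is attached at the sulfonamide, and no compound without a sulfonamide has been measured. The expectation is therefore uncertain. Compound 4 is expected to give about 300 nM, in a range from 30 nM to 3000 nM. This expected value would mean a 1.8-fold higher number from compound 3 to compound 4 (0.26 log units; within the scatter).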

Compound 4, half-maximal inhibitory concentration: 234 nM
Compound 4: the middle estimate sits 1.3-fold (0.11 log units) above what was measured; measured number inside the range.
By their numbers in this assay, from the lowest: compound 2; then compound 1; then compounds 3 and 4 (each within the scatter of the next).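

In this assay the step from the sulfonamide to an amine without sulfur gives a 1.4-fold higher number from compound 3 to compound 4 (0.15 log units; within the scatter), so at this position (dimethylamino)methyl and (phenylsulfonyl)amino cannot be told apart. The same replacement costs far more against the alkylsulfonyl groups, with a 59-fold higher number from compound 1 to compound 4 (1.77 log units; beyond the scatter) and a 590-fold higher number from compound 2 to compound 4 (2.77 log units; beyond the scatter), so holding a sulfonyl group here does not by itself separate compound 3 from compound 4. Nothing available accounts for these steps.

The compounds shown leave open how a primary amine or a morpholine would read at this position. They also leave open whether a longer chain carrying the dimethylamino group would differ from compound 4.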